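A few compounds are considered here, and "the series" means these few. Any claim that something is new, unique, unknown or untested is made for them only; others in the source may bear on it.

Compound 1 `O=c1[nH]cnc2c1c(-c1cccs1)cn2[C@@H]1O[C@H](CO)[C@@H](O)[C@H]1O` — in an ADME assay on MRC5 cells (Homo sapiens), read by MTT assay, with a stated time of 72 h (a higher number here means a weaker inhibitor, a lower number a stronger inhibitor), compound 1 gives > 100000 nM, which is a limit of the assay and not a number.
Compound 2 `O=c1[nH]cnc2c1c(-c1ccsc1)cn2[C@@H]1O[C@H](CO)[C@@H](O)[C@H]1O` — in this assay compound 2 gives > 100000 nM, again a limit of the assay rather than a number.

For the measured compounds named here, compound 2 therefore stands at the upper edge of what this assay reports; both values shown sit at the same limit, (the limit of > 100000 nM in this assay, at which 2 of the 2 values shown sit), so no compound here has a measured number. Going by the values given here, the one step between measured compounds, a step that the two limits leave unreadable from compound 1 to compound 2, cannot be read for size, since both ends are limits.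

Compound 3 `O=c1[nH]cnc2c1c(-c1ccccc1)cn2[C@@H]1O[C@H](CO)[C@@H](O)[C@H]1O` differs from compound 2 in one place: phenyl in place of thiophen-3-yl on an aromatic carbon. Among the compounds with values here, no measured step with a readable size bears on this exchange of one aromatic ring for another on the same carbon of the shared core, so nothing in the data supports expecting movement in either direction beyond the scatter.

Compound 3 is accordingly expected to remain at the limit of this assay, with an estimated value of 100000 nM, in a range from 40000 nM to 300000 nM. The expected step from compound 2, a number no higher from compound 2 to compound 3 (the limit leaves the size open), is thus estimated to be essentially none.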

Compound 3, half-maximal inhibitory concentration: > 100000 nM
Compound 3: only a limit was reported; the forecaster's own chance of this, stated with the estimate: 80%; the middle value sits exactly at the limit.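

In this assay compound 3 gives > 100000 nM, a limit of the assay and not a number, so the steps linking compound 1, compound 2 and compound 3 cannot be read for size. The compounds shown leave open how far each lies past that limit, and whether any group on this aromatic carbon would give a measured number: the limit of > 100000 nM in this assay, at which 3 of the 3 values shown sit.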